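Working notes on the aryl imine series

This account rests on a few compounds, and the source may have more. Where it says the series, first, only, none or still open, it means among the compounds named here.

Measured so far, in a functional assay on cells (Homo sapiens) for cytotoxicity, read by MTT assay, with a stated time of 24 h; a higher number here means a weaker inhibitor, a lower number a stronger inhibitor:
compound 1 `CCCCCCCCCCCCCCNC(=O)[C@H](CO)/N=C/c1ccc(O)cc1` gives 19300 nM
compound 2 `CCCCCCCCCCCCCCNC(=O)[C@H](CO)/N=C/c1ccccc1OC` gives 12500 nM
compound 3 `CCCCCCCCCCCCCCNC(=O)[C@H](CO)/N=C/c1cccc([N+](=O)[O-])c1` is not yet measured

Within the data shown here, compound 2 stands with compound 1 as its only comparator; the two numbers sit within the scatter of each other, the only measured step being a 1.5-fold lower number from compound 1 to compound 2 (0.19 log units; within the scatter). Compound 3 differs from compound 2 by 3-nitrophenyl in place of 2-methoxyphenyl on a carbon with a double bond to nitrogen. Among the measured compounds shown here, no measured step covers this exchange: the one step in hand swaps the aryl group at the same place, and it fell within the scatter, so the only evidence to hand is that aryl variation at this carbon has so far moved this assay little. The expectation for compound 3 is therefore a step of a 1.0-fold lower number from compound 2 to compound 3 (0.02 log units; within the scatter), no shift beyond the scatter in either direction. Compound 3 is estimated at 12000 nM, with a range from 5000 nM to 30000 nM.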

Compound 3, half-maximal inhibitory concentration: 104000 nM
For compound 3 the middle estimate is 8.7-fold (0.94 log units) below the measured one, and the stated range ends below it.
By their numbers in this assay, from the lowest: compounds 2 and 1 (each within the scatter of the next); then compound 3.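

Aryl exchange at this carbon with a double bond to nitrogen can move this assay beyond the scatter, which the step between compound 1 and compound 2 did not show. Putting 3-nitrophenyl in place of 2-methoxyphenyl gives an 8.3-fold higher number from compound 2 to compound 3 (0.92 log units; beyond the scatter), and putting it in place of 4-hydroxyphenyl gives a 5.4-fold higher number from compound 1 to compound 3 (0.73 log units; beyond the scatter), so compound 3 stands apart from both earlier compounds, which remain within the scatter of each other. Nothing to hand accounts for this shift.

The compounds shown leave open whether the higher number goes with the nitro group itself or with its place on the phenyl ring. Also open, from the compounds shown here alone, is whether a nitrile, an amine or a carboxylic acid on that ring would give a step of similar size.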